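Swapping Nitro for Dimethylamino on a Second Core

A few compounds are considered here, and "the series" means these few. Any claim that something is new, unique, unknown or untested is made for them only; others in the source may bear on it.

Four compounds share a sulfonate-linked tail and differ at one end of the molecule. Compound 1 `O=C(c1ccc([N+](=O)[O-])cc1)N1CCC(n2cncc2-c2ccc(OS(=O)(=O)c3cccc4cnccc34)cc2)CC1` and compound 2 `CN(C)c1ccc(C(=O)N2CCC(n3cncc3-c3ccc(OS(=O)(=O)c4cccc5cnccc45)cc3)CC2)cc1` are built on one core; compound 3 `O=C(c1ccc([N+](=O)[O-])cc1)N1CCN(c2cc(=O)[nH]c(=O)n2Cc2ccc(OS(=O)(=O)c3cccc4cnccc34)cc2)CC1` and compound 4 `CN(C)c1ccc(C(=O)N2CCN(c3cc(=O)[nH]c(=O)n3Cc3ccc(OS(=O)(=O)c4cccc5cnccc45)cc3)CC2)cc1` are built on another. The difference between the two cores is not broken down here.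

In an assay on THP-1 cells for antagonist activity at P2X purinoceptor 7 (Homo sapiens), read by ELISA, with a stated time of 30 min (a lower number here means a stronger inhibitor, a higher number a weaker inhibitor), compound 1 gives 8.29 nM, and compound 2 gives 2.19 nM. For the measured compounds named here, the only change between them dimethylamino in place of nitro on an aromatic carbon produced a step of a 3.8-fold lower number from compound 1 to compound 2 (0.58 log units; beyond the scatter). Compound 3, on the second core, gives 32 nM in this assay, the highest number among the three measured compounds.

Compound 4 differs from compound 3 by the same change (dimethylamino in place of nitro on an aromatic carbon), made at a place described in the same words as before. Because the earlier step was a 3.8-fold lower number from compound 1 to compound 2 (0.58 log units; beyond the scatter), a step of similar size is expected on the second core. Going by the values given here, the expected step from compound 3 to compound 4 in this assay is a 3.6-fold lower number from compound 3 to compound 4 (0.55 log units; beyond the scatter), which rests on the single earlier example and on the value of compound 3 32 nM. For compound 4 in this assay the estimated value is 9 nM. For compound 4 the expected range runs from 4 nM to 20 nM, wide enough to allow for the change transferring less fully to a different core.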

Compound 4, half-maximal inhibitory concentration: 1.33 nM
The estimate for compound 4 lay 6.8-fold (0.83 log units) above the measured number; measured number outside the range, below it.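

In this assay, the second core shows the same direction as the first when dimethylamino replaces nitro on the aromatic ring, with a 24-fold lower number from compound 3 to compound 4 (1.38 log units; beyond the scatter). The direction of the change therefore carried over between these two pairs of compounds, but its size did not, so a step measured on one core gave only a rough guide to the step on the other: the same change on two cores in this assay, a 3.8-fold lower number (0.58 log units; beyond the scatter) from compound 1 to compound 2 and a 24-fold lower number (1.38 log units; beyond the scatter) from compound 3 to compound 4, 6.4-fold (0.80 log units) apart, beyond the scatter of two such steps. This shows that the effect of this change depends on the core it is made on, at least in these four compounds, but it does not show which feature of the cores is responsible, how the change would behave on a third core, or why the sizes differ.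

The compounds shown leave open whether other groups in the same place, such as an amine with a single methyl group, a methoxy group or a carboxylic acid, would also give a larger step on the second core than on the first. They also leave open whether the gap between the two cores belongs to the exchange of nitro for dimethylamino alone or would appear with other exchanges at this position.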